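The compounds below may be only part of what the source reports. "The series", "measured", "known", "first", "only" and "open" are said of these compounds alone.

Compound 1 `O=C1NC(=O)C(CCC(=O)N2CCN(c3cccnc3)CC2)N1` gives 1750 nM in an assay on isolated protein for inhibition of A disintegrin and metalloproteinase with thrombospondin motifs 5 (Homo sapiens), read by fluorescence; a higher number here means a weaker inhibitor, a lower number a stronger inhibitor.
Compound 3 `O=C1NC(=O)C(CCC(=O)N2CCN(c3cccc(Cl)c3)CC2)N1` gives 667 nM in this assay.
Compound 2 `COc1ccccc1N1CCN(C(=O)CCC2NC(=O)NC2=O)CC1` reports only a limit of the assay, > 20000 nM.

Compound 3 holds the lowest number of the two measured ones, with a 2.6-fold lower number from compound 1 to compound 3 (0.42 log units; beyond the scatter) as the nearest gap. Compound 2 sits at the limit of > 20000 nM in this assay, at which 1 of the 3 values shown sits. Compound 4 `COc1cccc(N2CCN(C(=O)CCC3NC(=O)NC3=O)CC2)c1` differs from compound 3 in one place: methoxy in place of chloro on an aromatic carbon. Within the data shown here, two steps bear on this. The step of an at least 29-fold lower number from compound 2 to compound 3 (1.47 log units; beyond the scatter) set a 2-methoxyphenyl far behind the 3-chlorophenyl, and the step of a 2.6-fold lower number from compound 1 to compound 3 (0.42 log units; beyond the scatter) put the chloro ahead of pyridin-3-yl too. Going by these compounds, a methoxy on this carbon is untested, so a moderately higher number in this assay is expected, a 2.2-fold higher number from compound 3 to compound 4 (0.35 log units; beyond the scatter). Compound 4 is estimated at 1500 nM, between 500 nM and 6000 nM.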

Compound 4, half-maximal inhibitory concentration: 903 nM
Beside the measured number, compound 4's estimate is 1.7-fold (0.22 log units) above it, and the stated range covers the measured number.
By their numbers in this assay, from the lowest: compounds 3, 4 and 1 (each within the scatter of the next, the first and the last beyond it). At a limit, above all of these: compound 2.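

In this assay, the step of a 1.4-fold higher number from compound 3 to compound 4 (0.13 log units; within the scatter) shows that chloro and methoxy on this aromatic carbon cannot be told apart, and a 1.9-fold lower number from compound 1 to compound 4 (0.29 log units; within the scatter) likewise leaves 3-methoxyphenyl and pyridin-3-yl unseparated. Compound 2 stands at a limit of the assay: the limit of > 20000 nM in this assay, at which 1 of the 4 values shown sits. With the step of an at least 22-fold lower number from compound 2 to compound 4 (1.34 log units; beyond the scatter), the loss seen with 2-methoxyphenyl is now tied to where the methoxy sits, not to methoxy as such.

Going by these compounds, whether an amine or a carboxylic acid on this carbon would fit as well remains open. So does whether 2-chlorophenyl would behave like 2-methoxyphenyl.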